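Working notes: cyclobutyl in place of cyclopropyl

The compounds below may be only part of what the source reports. "The series", "measured", "known", "first", "only" and "open" are said of these compounds alone.

Measured so far in a physicochemical assay for lipophilicity, using the shake flask method, at pH 7.4 (a lower number here means a more polar compound, a higher number a more lipophilic compound), for three compounds:
- compound 1 `CCCC(Oc1ccc(-n2cc(OC)cn2)cc1)c1ccc(C(=O)NCCC(=O)O)cc1` gives 1.4
- compound 2 `O=C(O)CCNC(=O)c1ccc(C(Oc2ccc(-n3cc(C(F)(F)F)cn3)cc2)C2CC2)cc1` gives 1.7
- compound 3 `CCCC(Oc1ccc(-n2cc(C(=O)N(C)C)cn2)cc1)c1ccc(C(=O)NCCC(=O)O)cc1` gives 0.5

In this assay compound 2 and compound 1 lie within the scatter of each other, while compound 3 lies lower than both and beyond the scatter.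

The step to compound 4 `O=C(O)CCNC(=O)c1ccc(C(Oc2ccc(-n3cc(C(F)(F)F)cn3)cc2)C2CCC2)cc1` is a single substitution, cyclobutyl in place of cyclopropyl on a saturated chain carbon bound to an aromatic carbon and an oxygen on an aromatic ring and in words cyclobutyl in place of cyclopropyl on a saturated chain carbon bound to an aromatic carbon and an oxygen on an aromatic ring. Within the data shown here, no measured step changes that place. Among the measured compounds shown here, the one measured single-place step, a number 0.90 log units lower from compound 1 to compound 3 (beyond the scatter) for dimethylcarbamoyl in place of methoxy on an aromatic carbon, lies beyond the scatter but sits elsewhere on the structure and gives no size for this change. Compound 1 and compound 2 differ in more than one place, and their gap isolates nothing. The expectation rests on the change itself, which swaps one all-carbon ring for another with no hydrogen-bond donors or acceptors and no net charge on either side. A small upward step is expected, a number 0.30 log units higher from compound 2 to compound 4 (within the scatter) and no larger than the scatter. Compound 4 is expected at 2 within a range of 1.7 to 2.4 in the coming measurement.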

Compound 4, distribution coefficient: 2.6
For compound 4 the middle estimate is 0.60 log units below the measured one, and the stated range ends below it.
By their numbers in this assay, from the lowest: compound 3; then compounds 1 and 2 (each within the scatter of the next); then compound 4.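

In this assay the place on a saturated chain carbon bound to an aromatic carbon and an oxygen on an aromatic ring now has its first measured single-place step, and cyclobutyl in place of cyclopropyl gives a number 0.90 log units higher from compound 2 to compound 4 (beyond the scatter) with trifluoromethyl held constant. The change is confined to an all-carbon ring, from 3 heavy atoms to 4 heavy atoms, with no hydrogen-bond donors or acceptors and no net charge on either side, yet it has the same size as the step at the other measured place, a number 0.90 log units lower from compound 1 to compound 3 (beyond the scatter), in the opposite direction. Nothing on hand accounts for the size of this step.

The compounds shown leave open whether the same swap gives a step of this size with methoxy or dimethylcarbamoyl in place of trifluoromethyl, as the single pair carries trifluoromethyl on both sides. They also leave open how a cyclopentyl ring, or a cyclobutyl ring carrying an amine, would read at this place, so two ring sizes define no trend.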